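The source may report more compounds than this note shows. Statements on the series, on what has been measured and on what is new or still open speak of the compounds shown alone.

In an ADME assay on HeLa cells (Homo sapiens) for cytotoxicity, read by MTT assay, with a stated time of 72 h (on this read-out lower numbers stand for higher toxicity in this test and higher numbers for lower toxicity in this test), compound 3 `C(=C/c1ccccc1)\C=N\c1sc2c(c1-c1nc3ccccc3s1)CCCC2` gives 389 ug/mL, the second highest of the three numbers; compound 2 `C(=N/c1sc2c(c1-c1nc3ccccc3s1)CCCC2)\c1ccccc1` gives 333 ug/mL and compound 1 `Clc1ccc(/C=N/c2sc3c(c2-c2nc4ccccc4s2)CCCC3)c(Cl)c1` gives 542 ug/mL, each within the scatter of compound 3. Compound 4 `Oc1ccccc1/C=N/c1sc2c(c1-c1nc3ccccc3s1)CCCC2` differs from compound 3 by 2-hydroxyphenyl in place of 2-phenylethenyl on a carbon with a double bond to nitrogen. The changes already measured on this carbon were a 1.6-fold lower number from compound 1 to compound 2 (0.21 log units; within the scatter), a 1.4-fold lower number from compound 1 to compound 3 (0.14 log units; within the scatter) and a 1.2-fold higher number from compound 2 to compound 3 (0.07 log units; within the scatter): all within the scatter, so none of the groups tried at this position has moved this assay beyond it. Going by the values given here, no measured step covers a hydroxyl on this ring. For compound 4 the expected change is therefore none beyond the scatter, a 1.0-fold lower number from compound 3 to compound 4 (0.01 log units; within the scatter). Compound 4 is estimated at 380 ug/mL, with a range of 190 ug/mL to 760 ug/mL.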

Compound 4, half-maximal cytotoxic concentration: 122 ug/mL
For compound 4 the middle estimate is 3.1-fold (0.49 log units) above the measured one, outside the stated range (below it).
By their numbers in this assay, from the lowest: compound 4; then compounds 2, 3 and 1 (each within the scatter of the next).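

In this assay the carbon with a double bond to nitrogen can move the number beyond the scatter: there is a 3.2-fold lower number from compound 3 to compound 4 (0.50 log units; beyond the scatter) and a 2.7-fold lower number from compound 2 to compound 4 (0.44 log units; beyond the scatter) and also a 4.4-fold lower number from compound 1 to compound 4 (0.65 log units; beyond the scatter) while the three earlier groups stayed within it of one another. The step from the phenyl compound is only hydroxy in place of hydrogen on an aromatic carbon, so that single change suffices for a shift towards higher toxicity in this test. No measurement shown bears on the reason for the shift.

Going by these compounds, whether the free hydroxy itself is required remains open. A methoxy or an amine in its place would test that.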